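Returning an aromatic ring to the dichlorophenyl core

A few compounds are considered here, and "the series" means these few. Any claim that something is new, unique, unknown or untested is made for them only; others in the source may bear on it.

Two compounds sharing a dichlorophenyl core joined to a lactone have been tested in an assay for inhibition of 3-hydroxy-3-methylglutaryl-coenzyme A reductase (Rattus norvegicus); on this read-out higher numbers stand for weaker inhibition and lower numbers for stronger inhibition. Compound 1 `Cc1cc(C)cc(-c2cc(Cl)cc(Cl)c2/C=C/[C@@H]2C[C@@H](O)CC(=O)O2)c1` carries a 3,5-dimethylphenyl group on the core and in this assay compound 1 gives 13 nM. Among the measured compounds shown here, compound 2 `O=C1C[C@H](O)C[C@@H](/C=C/c2c(Cl)cc(Cl)cc2CCc2ccccc2)O1` carries a phenethyl group in the same place, and in this assay compound 2 gives 430 nM, the highest of the two numbers measured, with compound 1 as its only neighbour. The change from compound 1 to compound 2 was a 33-fold higher number from compound 1 to compound 2 (1.52 log units; beyond the scatter).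

Compound 3 `O=C1C[C@H](O)C[C@@H](/C=C/c2c(Cl)cc(Cl)cc2-c2cccc(F)c2)O1` has not yet been measured. Its difference from compound 2 is 3-fluorophenyl in place of phenethyl on an aromatic carbon. For the measured compounds named here, this is close to a reversal of the only measured step, since an aromatic ring again sits directly on the core, as in compound 1. The step from compound 1 to compound 2 therefore bears on it, and it was large. Compound 3 is expected to move back towards compound 1, with an estimated step of a 17-fold lower number from compound 2 to compound 3 (1.24 log units; beyond the scatter). The estimate for compound 3 is 25 nM, with a range from 8 nM to 80 nM.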

Compound 3, half-maximal inhibitory concentration: 70 nM
Estimate against measurement, compound 3: 2.8-fold (0.45 log units) below, within the range that was stated.
By their numbers in this assay, from the lowest: compound 1; then compound 3; then compound 2.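

Placing an aromatic ring directly on the shared core again recovers part of what the phenethyl group lost in this assay, with a 6.1-fold lower number from compound 2 to compound 3 (0.79 log units; beyond the scatter), so both compounds with a directly attached ring give lower numbers than the phenethyl compound. The recovery is only partial, however, as a 5.4-fold higher number from compound 1 to compound 3 (0.73 log units; beyond the scatter) shows that a directly attached ring does not by itself set the number and that what this ring carries also matters. No measurement here explains why either step occurs.

In compound 1 and compound 3, the fluorine and the two methyl groups differ together, so the compounds shown cannot assign the remaining step to the fluorine, to the methyl groups or to their positions on the ring; a plain phenyl or a 3-methylphenyl group would help to separate these possibilities. Going by these compounds, it also remains open how this position would respond to a ring carrying an amine or a carboxylic acid, or to a plain butyl chain with no ring at all.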